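Filling the Open Position on the Core of Compound 2

A few compounds are considered here, and "the series" means these few. Any claim that something is new, unique, unknown or untested is made for them only; others in the source may bear on it.

Compound 2 `Nc1ncnc2c1nc(O)n2Cc1ccccc1` has the higher of the two numbers measured in a functional assay (spleen, spleen) for activation, with Mus musculus as the target (on this read-out higher numbers stand for an effect only at larger amounts of compound and lower numbers for an effect already at smaller amounts), giving 10 uM. Compound 1 `CCCCCNc1nc(N)c2nc(O)n(Cc3ccccc3)c2n1` gives 0.1 uM. The step of a 100-fold higher number from compound 1 to compound 2 (2.00 log units; beyond the scatter) shows what taking away the pentylamino group did. Compound 3 `CCCC[S+]([O-])c1nc(N)c2nc(O)n(Cc3ccccc3)c2n1` carries a group of 6 heavy atoms (4 carbon, 1 oxygen, 1 sulfur; no ring) in place of a hydrogen atom, on an aromatic carbon, at the site where compound 1 holds its pentylamino group. Because compound 1 gives 0.1 uM, a group of similar size there is expected to lower the number, though the entering group is not an amino group and may not recover the whole step. Compound 3 is therefore expected to give about 1 uM, between 0.1 uM and 10 uM. That expected number would mean a step of a 10-fold lower number from compound 2 to compound 3 (1.00 log units; beyond the scatter).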

Compound 3, minimum effective concentration: 0.01 uM
Beside the measured number, compound 3's estimate is 100-fold (2.00 log units) above it, and the stated range ends above it.
By their numbers in this assay, from the lowest: compound 3; then compound 1; then compound 2.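

In this assay, a group at this position does more than make up for the missing pentylamino group, giving a 1000-fold lower number from compound 2 to compound 3 (3.00 log units; beyond the scatter). An amino group is not required here for a low number: the group of 6 heavy atoms with sulfur and oxygen, in place of pentylamino, gives a 10-fold lower number from compound 1 to compound 3 (1.00 log units; beyond the scatter). No measurement at hand explains this gain.

The compounds shown leave open what the oxygen on the sulfur contributes, which a matching thioether would test. On these data alone, how a longer chain on the sulfur would read also remains open.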